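From 2-cyanobenzyl to 3-bromobenzyl

The source may report more compounds than this note shows. Statements on the series, on what has been measured and on what is new or still open speak of the compounds shown alone.

In a functional assay on A-375 cells (Homo sapiens) for antiproliferative activity, read by MTT assay, with a stated time of 24 h (a lower number here means a stronger inhibitor, a higher number a weaker inhibitor), compound 1 `COc1cc(OC)c(-c2coc3cc(OCC(=O)c4cccc(C(F)(F)F)c4)ccc3c2=O)cc1OC` gives > 10000 nM, which is a limit of the assay and not a number. Compound 3 `COc1cc(OC)c(-c2coc3cc(OCc4ccccc4C#N)ccc3c2=O)cc1OC` gives 990 nM, level within the scatter with compound 2 `COc1cc(OC)c(-c2coc3cc(OCc4ccc(F)cc4)ccc3c2=O)cc1OC` at 1720 nM. Compound 4 `COc1cc(OC)c(-c2coc3cc(OCc4cccc(Br)c4)ccc3c2=O)cc1OC` carries 3-bromophenyl in place of 2-cyanophenyl on a saturated chain carbon bound to an oxygen on an aromatic ring. The larger steps, an at least 5.8-fold lower number from compound 1 to compound 2 (0.76 log units; beyond the scatter) and an at least 10-fold lower number from compound 1 to compound 3 (1.00 log units; beyond the scatter), remove a carbonyl-bearing group, so they bear little on this change. Among the compounds with values here, the closest precedent swaps one substituted phenyl for another, a 1.7-fold lower number from compound 2 to compound 3 (0.24 log units; within the scatter), and stays within the scatter. An estimated 1.4-fold higher number from compound 3 to compound 4 (0.15 log units; within the scatter) is therefore expected, with no step beyond the scatter. Compound 4 is estimated at 1400 nM, with an expected range of 500 nM to 4000 nM.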

Compound 4, half-maximal inhibitory concentration: 1120 nM
The estimate for compound 4 lay 1.3-fold (0.10 log units) above the measured number; the measured number falls inside the stated range.
By their numbers in this assay, from the lowest: compounds 3, 4 and 2 (each within the scatter of the next). At a limit, above all of these: compound 1.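

In this assay, three differently substituted phenyl groups on a saturated chain carbon bound to an oxygen on an aromatic ring now sit level, with a 1.1-fold higher number from compound 3 to compound 4 (0.05 log units; within the scatter) and a 1.5-fold lower number from compound 2 to compound 4 (0.19 log units; within the scatter), so 3-bromophenyl, which has no nitrile, matches 2-cyanophenyl and 4-fluorophenyl here. The gap to the carbonyl-bearing compound 1 holds for this third phenyl group too, with an at least 8.9-fold lower number from compound 1 to compound 4 (0.95 log units; beyond the scatter). Compound 1 stands at a limit and not a number: the limit of > 10000 nM in this assay, at which 1 of the 4 values shown sits.

Whether the carbonyl or the 3-(trifluoromethyl)phenyl group in compound 1 accounts for that gap stays open. So does whether an amine, a carboxylic acid or a longer chain at this place would move the number beyond the scatter.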